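Hydroxymethyl to formyl on the shared core

The source may hold more compounds than are shown below. What is called first, only, known or untested is meant among the compounds shown, and "the series" means these compounds.

Compound 1 `C=C1CC[C@H]2O[C@@]2(C)[C@H](OC(=O)C=C(C)C)/C=C/[C@@](C)(CCC=C(C)C)C[C@H]1O` reads > 20000 nM in a functional assay on A549 cells (Homo sapiens) for antiproliferative activity, read by MTT assay, with a stated time of 72 h (a lower number here means a stronger inhibitor, a higher number a weaker inhibitor), and that value is a limit of the assay, not a number.

Going by the values given here, compound 2 `CC(C)=CCC[C@]1(C)/C=C/[C@@H](OC(=O)C=C(C)C)[C@]2(C)O[C@@H]2CC/C(CO)=C\C1` gives 8300 nM in this assay as the only true number so far, so it has no measured neighbour to be ranked against.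

Compound 3 `CC(C)=CCC[C@]1(C)/C=C/[C@@H](OC(=O)C=C(C)C)[C@]2(C)O[C@@H]2CC/C(C=O)=C\C1` carries formyl in place of hydroxymethyl on a double-bonded ring carbon and otherwise matches compound 2.

Among the compounds with values here, no measured step covers this change, so the expectation is a judgement starting from compound 2 at 8300 nM and resting on the structural change alone. The expected size is a 2.1-fold lower number from compound 2 to compound 3 (0.32 log units; beyond the scatter) as estimated here, a modest move toward stronger inhibition in this assay with little confidence in its direction.

Compound 3 is expected at 4000 nM with an estimated range of 1300 nM to 12000 nM in repeat measurements.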

Compound 3, half-maximal inhibitory concentration: 11000 nM
Estimate against measurement, compound 3: 2.8-fold (0.44 log units) below; the range from low to high includes it.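

In this assay, formyl in place of hydroxymethyl on the double-bonded ring carbon gives a 1.3-fold higher number from compound 2 to compound 3 (0.12 log units; within the scatter). Going by these compounds alone, this is the first single-place step, and it shows that this exchange, which goes from 1 hydrogen-bond donor to 0 and keeps 1 hydrogen-bond acceptor, does not separate the two compounds in this assay. Compound 1 remains a limit of the assay and not a number: the limit of > 20000 nM in this assay, at which 1 of the 3 values shown sits.

As far as these compounds go, whether any group on this ring carbon can move the value beyond the scatter stays open; a carboxylic acid, an aminomethyl group or a longer chain there would address that question. How the ((2-methylprop-1-en-1-yl)carbonyl)oxy group or the 4-methylpent-3-en-1-yl group contributes also stays open, since no single-place step shown covers either.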